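Swapping Dichlorobenzyl for Methoxybenzyl on a Diamine Core

The source may report more compounds than this note shows. Statements on the series, on what has been measured and on what is new or still open speak of the compounds shown alone.

Two measured compounds share a core bearing two amino groups and a phenyl substituent. Compound 1 `CCOC(=O)[C@H](CCC(=O)O)NC(=O)c1ccc(CNc2nc3cc(N)cc(N)c3nc2-c2ccccc2)cc1` carries a glutamate ester attached through an amide; in a functional assay on U-251 cells (Homo sapiens) for inhibition, read by sulforhodamine B assay, with a stated time of 48 h (on this read-out higher numbers stand for weaker inhibition of growth and lower numbers for stronger inhibition of growth), compound 1 gives only a limit, < 100000 nM, and no number. Compound 2 `Nc1cc(N)c2nc(-c3ccccc3)c(NCc3ccc(Cl)c(Cl)c3)nc2c1` carries a 3,4-dichlorobenzyl group; in this assay compound 2 gives 2090 nM. Going by the values given here, that is the single numerical value among the measured compounds, so compound 2 stands alone as the one firm reference point. Compound 3 `COc1ccc(CNc2nc3cc(N)cc(N)c3nc2-c2ccccc2)cc1` has not yet been measured; it differs from compound 2 by 4-methoxyphenyl in place of 3,4-dichlorophenyl on a saturated chain carbon bound to a nitrogen on an aromatic ring. Among the compounds with values here, no measured pair isolates this change, so the numbers give no direct guide to its size. The author expects a modest loss of growth inhibition, a step of a 2.4-fold higher number from compound 2 to compound 3 (0.38 log units; beyond the scatter) that may not lie far beyond the scatter. Compound 3 is estimated at 5000 nM, with a range from 1500 nM to 20000 nM.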

Compound 3, concentration for 50% growth inhibition: 13500 nM
Estimate against measurement, compound 3: 2.7-fold (0.43 log units) below; the measured number falls inside the stated range.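

With compound 3, the position on a saturated chain carbon bound to a nitrogen on an aromatic ring has its first readable step: in this assay, 4-methoxyphenyl in place of 3,4-dichlorophenyl gives a 6.5-fold higher number from compound 2 to compound 3 (0.81 log units; beyond the scatter). The earlier compounds shown here offered one number and one limit, whereas this pair shows that growth inhibition responds to the group at this position, even though the two groups have the same number of heavy atoms and the entering one adds a hydrogen-bond acceptor. Nothing measured here accounts for the step.

The compounds shown do not separate the loss of the two chlorines from the arrival of the methoxy group. From the compounds shown here alone, how an unsubstituted benzyl group, or a benzyl group bearing an amine, would read in this assay remains open.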